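Nitro for Trifluoromethoxy on the Benzamide Ring

The source may hold more compounds than are shown below. What is called first, only, known or untested is meant among the compounds shown, and "the series" means these compounds.

Measured compounds:
compound 1 `CCOc1ccc(C(=O)Nc2cccc(NC(=O)COc3ccc4c(=O)ccoc4c3)c2)cc1`: 9 nM
compound 2 `O=C(COc1ccc2c(=O)ccoc2c1)Nc1cccc(NC(=O)c2ccc(OC(F)(F)F)cc2)c1`: 77 nM

Of the two compounds measured in an assay on isolated protein for inhibition of Rho-associated protein kinase 2 (Homo sapiens), read by scintillation counting, radiometric assay and 33P incorporation, with a stated time of 40 min, in the presence of a further agent that is not named here (a lower number here means a stronger inhibitor, a higher number a weaker inhibitor), compound 2 gives the higher number, with an 8.6-fold higher number from compound 1 to compound 2 (0.93 log units; beyond the scatter) separating it from compound 1. Compound 3 `O=C(COc1ccc2c(=O)ccoc2c1)Nc1cccc(NC(=O)c2ccc([N+](=O)[O-])cc2)c1` carries the change (nitro in place of trifluoromethoxy on an aromatic carbon). Among the measured compounds shown here, no measured step makes this same change; the one step at this position, an 8.6-fold higher number from compound 1 to compound 2 (0.93 log units; beyond the scatter), concerns a different group and so only loosely bears on it. A step of modest size in either direction is therefore expected, and compound 3 is estimated at 40 nM (range 10 nM to 200 nM), a step of a 1.9-fold lower number from compound 2 to compound 3 (0.28 log units; within the scatter).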

Compound 3, half-maximal inhibitory concentration: 15 nM
Estimate against measurement, compound 3: 2.7-fold (0.43 log units) above; low and high end bracket the measured number.
By their numbers in this assay, from the lowest: compounds 1 and 3 (each within the scatter of the next); then compound 2.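

In this assay, nitro in place of trifluoromethoxy on this aromatic carbon gives a 5.1-fold lower number from compound 2 to compound 3 (0.71 log units; beyond the scatter), so the weaker reading of compound 2 does not extend to every replacement of ethoxy. Nitro and ethoxy are not separated here, with a 1.7-fold higher number from compound 1 to compound 3 (0.22 log units; within the scatter), which leaves trifluoromethoxy as the only one of the three groups set apart from both others. No measurement shown accounts for this difference.

The compounds shown leave open how an amine, a carboxylic acid or a longer alkoxy chain would read at this position. They also leave open whether these groups would rank the same way elsewhere on the ring.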